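Aryl sulfonates: from 3-nitrophenyl to 4-methoxyphenyl

The source may report more compounds than this note shows. Statements on the series, on what has been measured and on what is new or still open speak of the compounds shown alone.

In a functional assay on HT-29 cells (Homo sapiens) for antiproliferative activity, read by sulforhodamine B assay, with a stated time of 48 h (a lower number here means a stronger inhibitor, a higher number a weaker inhibitor), compound 1 (`CCCN1CCN(c2ccc(S(=O)(=O)Oc3c(Cl)cc(Cl)cc3Cl)cc2)C1=O`) gives 56000 nM as its reading. Compound 2 (`CCCN1CCN(c2ccc(S(=O)(=O)Oc3cccc(F)c3)cc2)C1=O`) gives 18000 nM on the same read-out. Compound 3 (`CCCN1CCN(c2ccc(S(=O)(=O)Oc3cccc([N+](=O)[O-])c3)cc2)C1=O`) gives > 100000 nM and this is a limit of the assay, not a number. For compound 3 the record is the limit of > 100000 nM in this assay, at which 1 of the 3 values shown sits, and nothing finer.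

Compound 4 (`CCCN1CCN(c2ccc(S(=O)(=O)Oc3ccc(OC)cc3)cc2)C1=O`) is not yet measured. It carries 4-methoxyphenyl in place of 3-nitrophenyl on an oxygen, with the full count of the change in 4-methoxyphenyl in place of 3-nitrophenyl on an oxygen as computed.

All three measured steps alter the group on that oxygen. The closest is an at least 5.5-fold higher number from compound 2 to compound 3 (0.74 log units; beyond the scatter) for nitro in place of fluoro, and the others are a 3.1-fold lower number from compound 1 to compound 2 (0.49 log units; beyond the scatter) and an at least 1.7-fold higher number from compound 1 to compound 3 (0.25 log units; that floor lies within the scatter) with the last floor inside the scatter. For the measured compounds named here, no measured compound carries methoxy, so the guide is loose. Leaving the 3-nitrophenyl of compound 3 is expected to recover part of an at least 5.5-fold higher number from compound 2 to compound 3 (0.74 log units; beyond the scatter) and no more. The expected step is an at least 3.3-fold lower number from compound 3 to compound 4 (0.52 log units; beyond the scatter) toward a lower number. Compound 4 is estimated at 30000 nM with an expected range from 10000 nM to 90000 nM in this read-out.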

Compound 4, half-maximal inhibitory concentration: 16000 nM
Compound 4: middle estimate off by 1.9-fold (0.27 log units), on the high side, and the stated range covers the measured number.
By their numbers in this assay, from the lowest: compounds 4 and 2 (each within the scatter of the next); then compound 1. At a limit, above all of these: compound 3.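

In this assay, the oxygen bound to the sulfonyl sulfur now carries a second aryl group that cannot be told apart from 3-fluorophenyl: a 1.1-fold lower number from compound 2 to compound 4 (0.05 log units; within the scatter). The same change of group, 4-methoxyphenyl for 2,4,6-trichlorophenyl, gives a step beyond the scatter, a 3.5-fold lower number from compound 1 to compound 4 (0.54 log units; beyond the scatter), so compound 2 is no longer the only compound shown to improve on compound 1 at this place. Leaving 3-nitrophenyl gives an at least 6.2-fold lower number from compound 3 to compound 4 (0.79 log units; beyond the scatter), and this is only a floor, its true size unknown, as compound 3 has a limit of the assay and not a number: the limit of > 100000 nM in this assay, at which 1 of the 4 values shown sits.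

On these data alone, whether the reading follows the substituent or the place it occupies stays open, as compound 2 and compound 4 differ in both. As far as these compounds go, how an amine or a carboxylic acid on this aryl group would read is also open.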